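Para-chloro on the benzylidene ring of the acetoxymethyl enone

The compounds below may be only part of what the source reports. "The series", "measured", "known", "first", "only" and "open" are said of these compounds alone.

For the measured compounds named here, compound 3 `CC(=O)OC/C(=C\c1ccccc1)C(=O)c1ccccc1` gives 4800 nM in a functional assay on SW1573 cells (Homo sapiens) for inhibition, read by sulforhodamine B assay, with a stated time of 48 h (a higher number here means a weaker inhibitor of growth, a lower number a stronger inhibitor of growth), second highest of the three numbers so far. Its nearest neighbour is compound 1 `O=C(/C(=C/c1ccc(Cl)cc1)CCl)c1ccccc1` with 3900 nM, within the scatter of compound 3; the furthest is compound 2 `CCC(/C=C(\COC(C)=O)C(=O)c1ccccc1)CC` with 77000 nM. Going by the values given here, the only measured single-point step, a 16-fold lower number from compound 2 to compound 3 (1.21 log units; beyond the scatter), concerns the other end of the chain and does not bear on the present change. Compound 4 `CC(=O)OC/C(=C\c1ccc(Cl)cc1)C(=O)c1ccccc1` differs from compound 3 by chloro in place of hydrogen on an aromatic carbon, para to a large group. Compound 1 already carries this chloro and sits within the scatter of compound 3, so no step beyond the scatter is expected; the estimated step is a 1.2-fold lower number from compound 3 to compound 4 (0.08 log units; within the scatter). Compound 4 is therefore expected near 4000 nM, in the range 1500 nM to 11000 nM.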

Compound 4, concentration for 50% growth inhibition: 2600 nM
Estimate against measurement, compound 4: 1.5-fold (0.19 log units) above, and the stated range covers the measured number.
By their numbers in this assay, from the lowest: compounds 4, 1 and 3 (each within the scatter of the next); then compound 2.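

In this assay, phenyl to 4-chlorophenyl, with chloro para to a large group, stays within the scatter (a 1.8-fold lower number from compound 3 to compound 4 (0.27 log units; within the scatter)), and acetoxy in place of chloro on the saturated chain carbon does too (a 1.5-fold lower number from compound 1 to compound 4 (0.18 log units; within the scatter)). The large gap to the pentan-3-yl compound remains with the chloro present (a 30-fold lower number from compound 2 to compound 4 (1.47 log units; beyond the scatter)). No measurement on hand bears on the cause of these steps.

Open, on these data alone, is whether methoxy or nitrile at this ring place would give a step beyond the scatter. Also open, as far as these compounds go, is what an amine in place of acetoxy would do.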